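This account rests on a few compounds, and the source may have more. Where it says the series, first, only, none or still open, it means among the compounds named here.

Compound 1 `CC(C)CCOC(=O)/C(C#N)=C/c1ccc(O)c(O)c1`: 27.2%
Compound 2 `N#C/C(=C\c1ccc(O)c(O)c1)C(=O)OC1CCCCC1`: 55.3%
Compound 3 `CC(C)CCOC(=O)/C(C#N)=C/c1ccoc1`: 82.2%

Of the compounds shown here, three have been tested in a functional assay on the whole organism (strain CD1) for inhibition, with Mus musculus as the target, with stated times of 15 min and 20 min, at a dose of 10 mg/kg by the subcutaneous route; on this read-out lower numbers stand for less inhibition and higher numbers for more inhibition at the one dose given (going by the name of the read-out). In this assay compound 1 gives 27.2%, compound 2 gives 55.3% and compound 3 gives 82.2%. Compound 1 and compound 2 share a core and differ in one place: cyclohexyl in place of isopentyl on an oxygen next to a carbonyl group This change brought a number 28.1 percentage points higher from compound 1 to compound 2 (beyond the scatter). Compound 3 carries a different core; how its core differs from that of compound 1 is not broken down here. Compound 4 `N#C/C(=C\c1ccoc1)C(=O)OC1CCCCC1` has not yet been measured. It stands to compound 3 as compound 2 stands to compound 1: cyclohexyl in place of isopentyl on an oxygen next to a carbonyl group The place of the change reads the same in both pairs. It is the same change. Among the measured compounds shown here, the earlier step is the only guide to its size, yet compound 3 already gives 82.2%, so a full repeat of that step would pass the top of the scale. A smaller step is therefore expected, a number 7.8 percentage points higher from compound 3 to compound 4 (within the scatter). Compound 4 is estimated to reach 90%, with a likely range from 72% to 99%.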

Compound 4, a percentage reported as inhibition, in the whole organism at one dose (the size of the read-out at that dose, not a potency): 91.2%
Compound 4: the middle estimate sits 1.2 percentage points below what was measured; the range from low to high includes it.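

On the core of compound 3, putting cyclohexyl in place of isopentyl on an oxygen next to a carbonyl group gives, in this assay, a number 9 percentage points higher from compound 3 to compound 4 (within the scatter), so on this core the change cannot be told apart from the ordinary spread of repeat measurements. The change therefore does not carry over from one core to the other with the same size: the same change on two cores in this assay, a number 28.1 percentage points higher (beyond the scatter) from compound 1 to compound 2 and a number 9 percentage points higher (within the scatter) from compound 3 to compound 4, 19.1 percentage points apart, beyond the scatter of two such steps

Two pairs do not show why the steps differ: compound 3 already gives 82.2%, close to the top of a percentage scale, and the data cannot separate that limited room from an effect of the core itself.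

The compounds shown leave open how other groups on that oxygen would behave, such as a longer chain, a phenyl ring or a chain carrying an amine. Also open, from the compounds shown here alone, is the size of this same change on a third core, which would help show which of the two steps is more typical of the series.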